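The source may hold more compounds than are shown below. What is called first, only, known or untested is meant among the compounds shown, and "the series" means these compounds.

Measured compounds:

compound 1, `COc1ccc(-c2c(-c3ccc(OC)cc3)n(Cc3ccccc3)c3ncn([C@@H]4CCCC[C@H]4O)c(=N)c23)cc1`, in a functional assay on PC-3M cells (Homo sapiens) for antiproliferative activity, read by microscopy, with a stated time of 24 h (on this read-out higher numbers stand for weaker inhibition and lower numbers for stronger inhibition), gives > 20000 nM.
compound 2, `OCCCNc1ncnc2c1c(-c1ccccc1)c(-c1ccccc1)n2Cc1ccccc1`, in this assay gives > 20000 nM.
compound 3, `N=c1c2c(-c3ccccc3)c(-c3ccccc3)n(Cc3ccccc3)c2ncn1CCNc1ccncc1`, in this assay gives 6590 nM; 6610 nM (2 entries).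

Compound 1 stands at a limit only; its entry in this assay is not a number. The same holds for compound 2, which is also reported as a limit. Compound 3 is the only compound of the three with a measured number, and its two entries agree, as shown by the several entries of compound 3 in this assay, 6590 nM; 6610 nM (2 entries). Across the series, most of what is shown sits at the limit, as shown by the limit of > 20000 nM in this assay, at which 2 of the 3 values shown sit. Within the data shown here, no pair of measured compounds differs in a single place, so no measured step is available.

Compound 4, `COc1ccc(-c2c(-c3ccc(OC)cc3)n(Cc3ccccc3)c3ncn(C4CCOCC4)c(=N)c23)cc1`, is the next compound to be measured in this assay. It differs from compound 1 as follows: oxan-4-yl in place of 2-hydroxycyclohexyl on an aromatic nitrogen. With compound 1 itself at a limit, there is no measured anchor to project from. The expected step from compound 1 to compound 4 is a step that the limit leaves unreadable from compound 1 to compound 4, that is, no change beyond the usual scatter in either direction. Compound 4 is therefore expected to give about 25000 nM in this assay, within 8000 nM to 80000 nM, and most likely to be reported as a limit rather than a number.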

Compound 4, half-maximal inhibitory concentration: > 20000 nM
Compound 4 ended at the assay's limit; the forecaster's own chance of this, stated with the estimate: 70%; the middle value does not contradict the limit.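

In this assay compound 4 gives > 20000 nM, a limit and not a number. Among these compounds, compound 1 is also reported only as a limit, so no step between compound 1 and compound 4 can be read. The compounds shown leave open whether oxan-4-yl and 2-hydroxycyclohexyl on an aromatic nitrogen differ in antiproliferative activity.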